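The source may report more compounds than this note shows. Statements on the series, on what has been measured and on what is new or still open speak of the compounds shown alone.

Measured in a functional assay on the whole organism (strain Wistar) for inhibition, with Rattus norvegicus as the target, read by paw edema, with stated times of 30 min and 2.5 h, at a dose of 20 mg/kg by the intraperitoneal route; a higher number here means more inhibition at the dose given (going by the name of the read-out), a lower number less inhibition:
compound 1 `CCCc1nnc2sc(-c3c[nH]nc3-c3ccccc3)nn12` gives 56.9%
compound 2 `CCCc1nnc2sc(-c3c[nH]nc3-c3ccc(F)cc3)nn12` gives 12%
compound 3 `CCc1nnc2sc(-c3c[nH]nc3-c3ccc(Cl)cc3Cl)nn12` gives 25.5%

Compound 3 stands second of the three numbers, beyond the scatter below compound 1 and beyond the scatter above compound 2. Compound 4 `CCCc1nnc2sc(-c3c[nH]nc3-c3ccc(Cl)cc3Cl)nn12` differs from compound 3 by methyl in place of hydrogen on a saturated chain carbon, two bonds along the chain from an aromatic carbon. Among the measured compounds shown here, the single measured step, a number 44.9 percentage points lower from compound 1 to compound 2 (beyond the scatter), concerns a substituent on the aromatic ring and leaves the chain untouched, so no measured step bears directly on the change from compound 3 to compound 4. Compounds 1 and 2 carry the propyl chain and compound 3 the ethyl chain, but these compounds also differ on the aromatic ring, so their values do not isolate the chain change. With nothing bearing on it, the expected step is one that stays within the scatter: a number 0.5 percentage points higher from compound 3 to compound 4 (within the scatter). Compound 4 is therefore expected to give about 26% in this assay, with a wide range from 10% to 45% reflecting the lack of any comparison on this change.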

Compound 4, a percentage reported as inhibition, in the whole organism at one dose (the size of the read-out at that dose, not a potency): 23.5%
The estimate for compound 4 lay 2.5 percentage points above the measured number; measured number inside the range.
By their numbers in this assay, from the lowest: compound 2; then compounds 4 and 3 (each within the scatter of the next); then compound 1.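

In this assay, among the compounds shown here, the chain change can now be read on its own for the first time: with the 2,4-dichlorophenyl group held constant, ethyl to propyl gives a number 2 percentage points lower from compound 3 to compound 4 (within the scatter), so for this pair, methyl in place of hydrogen on a saturated chain carbon leaves the read-out unchanged. With the propyl chain held constant, the aromatic group can be compared across three compounds: 2,4-dichlorophenyl in place of 4-fluorophenyl gives a number 11.5 percentage points higher from compound 2 to compound 4 (beyond the scatter), and 2,4-dichlorophenyl in place of phenyl gives a number 33.4 percentage points lower from compound 1 to compound 4 (beyond the scatter), leaving the unsubstituted phenyl of compound 1 clearly highest among these propyl compounds. No measured evidence accounts for the chain step or the ring steps.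

From the compounds shown here alone, whether the chain change is equally silent with phenyl or 4-fluorophenyl remains open, as neither has an ethyl partner here. Also open, going by these compounds, is how a longer chain such as butyl, or an amine at the chain end, would behave.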